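Swapping a Carbamoyl for a Bromophenyl at the Ring Oxygen

The source may report more compounds than this note shows. Statements on the series, on what has been measured and on what is new or still open speak of the compounds shown alone.

Measured in a functional assay on a cell-free system (plasma, Oryctolagus cuniculus) for inhibition, with stated times of 5 min, 1 min and 6 min; a lower number here means a stronger inhibitor, a higher number a weaker inhibitor:
compound 1 `CCOC(=O)c1c(C)nc(-c2ccc(OCC(C)C)c(C#N)c2)n1O` gives 16800 nM;
compound 2 `CCOC(=O)c1c(C)nc(-c2ccc(C#N)cc2)n1OC` gives 13400 nM;
compound 3 `CCOC(=O)c1c(C)nc(-c2cccc(C#N)c2)n1OCC(N)=O` gives > 30000 nM.

The value for compound 3 is a limit of this assay (the limit of > 30000 nM in this assay, at which 1 of the 3 values shown sits), not a number. Compound 3 thus sits at the weak end of what has been measured here, while compounds 1 and 2 give numbers. Compound 4 `CCOC(=O)c1c(C)nc(-c2cccc(C#N)c2)n1OCc1ccc(Br)cc1` is compound 3 with one change: 4-bromophenyl in place of carbamoyl on a saturated chain carbon bound to an oxygen on an aromatic ring. Among the compounds with values here, no measured pair shows this change, so its size and direction are open. Compound 4 is expected to give a number rather than a limit, estimated at 20000 nM with a range of 6000 nM to 60000 nM. That expectation means a step of an at least 1.5-fold lower number from compound 3 to compound 4 (0.17 log units; that floor lies within the scatter), estimated rather than measured.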

Compound 4, half-maximal inhibitory concentration: 24600 nM
Compound 4: middle estimate off by 1.2-fold (0.09 log units), on the low side; measured number inside the range.
By their numbers in this assay, from the lowest: compounds 2, 1 and 4 (each within the scatter of the next). At a limit, above all of these: compound 3.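

With 4-bromophenyl in place of carbamoyl on this saturated chain carbon, this assay returns a number for compound 4, which shows that a carbamoyl is not needed at this position for a measurable value. The change is a step of an at least 1.2-fold lower number from compound 3 to compound 4 (0.08 log units; that floor lies within the scatter) and so does not establish a real gain. Compound 3 remains a limit and not a number: the limit of > 30000 nM in this assay, at which 1 of the 4 values shown sits.

On these data alone, whether a plain phenyl, a 4-chlorophenyl or a carboxylic acid on the same carbon would give a number like that of compound 4 stays open.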